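A few compounds are considered here, and "the series" means these few. Any claim that something is new, unique, unknown or untested is made for them only; others in the source may bear on it.

Compound 1, `Oc1ccccc1CNc1ncnc2c1ncn2C1CCCCO1`, is the simplest of the four structures considered here. In an ADME assay on K562 cells (Homo sapiens) for cytotoxicity, with a stated time of 72 h (on this read-out higher numbers stand for weaker inhibition and lower numbers for stronger inhibition), compound 1 gives only a limit of the assay, > 100000 nM. Compound 2, `COc1cccc(CNc2ncnc3c2ncn3C2CCCCO2)c1O`, carries the change (methoxy in place of hydrogen on an aromatic carbon). Compound 2 likewise reaches only a limit in this assay, > 100000 nM. The step from compound 1 to compound 2 in this assay is therefore a step that the two limits leave unreadable from compound 1 to compound 2, and the evidence on it is no more than the limit of > 100000 nM in this assay, at which 2 of the 3 values shown sit.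

Compound 3, `COc1cccc(OC)c1CNc1ncnc2c1ncn2C1CCCCO1`, has a core that differs from that of compound 1 in a way that is not broken down here. In this assay, among the compounds with values here, compound 3 gives 10300 nM, the only number among the three measured compounds.

Compound 4, `COc1cc(OC)c(CNc2ncnc3c2ncn3C2CCCCO2)c(OC)c1`, is not yet measured. It differs from compound 3 by methoxy in place of hydrogen on an aromatic carbon. This is the same kind of change as that from compound 1 to compound 2, but not the same: in compound 2 the new methoxy sits ortho to a hydroxy group and meta to a large group, whereas in compound 4 it sits meta to two methoxy groups and para to a large group. Within the data shown here, the one measured instance of this kind of change is unreadable, so it offers no guide to the size of the step. The expected step from compound 3 to compound 4 in this assay is therefore estimated as a 1.5-fold higher number from compound 3 to compound 4 (0.16 log units; within the scatter), resting on nothing more than the value of compound 3, 10300 nM, and the absence of a readable precedent. Compound 4 is thus expected to give about 15000 nM in this assay, within a range from 4000 nM to 70000 nM.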

Compound 4, half-maximal inhibitory concentration: > 50000 nM
Compound 4: a limit, no number; the forecaster's own chance of this, stated with the estimate: 25%; middle value at least 3.3-fold (0.52 log units) away from the limit.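

On the core of compound 3, methoxy in place of hydrogen on an aromatic carbon gives in this assay an at least 4.8-fold higher number from compound 3 to compound 4 (0.68 log units; beyond the scatter), so on this core the change goes with a weaker read-out, by an amount that has only a lower bound. Compound 4 gives a limit of the assay and not a number, > 50000 nM. Here the new methoxy sits meta to two methoxy groups and para to a large group, a different place from the one it takes in compound 2, and the same kind of change from compound 1 to compound 2 cannot be read, so this result does not show that the change carries from one core to another: the limit of > 100000 nM in this assay, at which 2 of the 4 values shown sit.

The compounds shown leave open how an ethoxy group, a fluorine atom or an amine would read in this assay at the place taken by the new methoxy of compound 4. Within the data shown here, they also leave open what a carboxylic acid or a longer chain would give in place of one of the two methoxy groups of compound 3, the only compound here with a number.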